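Swapping the Thiophene Ring on the Edema Series

The source may report more compounds than this note shows. Statements on the series, on what has been measured and on what is new or still open speak of the compounds shown alone.

Of the compounds shown here, two of a shared core have been tested so far. Compound 1 `CCOC(=O)C1=C(C)NC(C)=C(C(=O)OCC)C1c1ccc(OCC(=O)Nc2c(C)cccc2C)cc1` carries 2,6-dimethylphenyl on an amide-type nitrogen; in a functional assay on the whole organism (strain Wistar) for inhibition, with Rattus norvegicus as the target, read by paw edema, with stated times of 30 min and 2 h, at a dose of 20 mg/kg (a lower number here means less inhibition, a higher number more inhibition at the dose given (going by the name of the read-out)), compound 1 gives 47.8%. Compound 2 `CCOC(=O)C1=C(C)NC(C)=C(C(=O)OCC)C1c1ccc(OCC(=O)NNC(=O)c2cccs2)cc1` carries ((thiophen-2-yl)carbonyl)amino in that place instead, and in this assay compound 2 gives 62.2%, the highest of the two numbers; the step of a number 14.4 percentage points higher from compound 1 to compound 2 (beyond the scatter) is modest but beyond the scatter.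

Compound 3 `CCOC(=O)C1=C(C)NC(C)=C(C(=O)OCC)C1c1ccc(OCC(=O)NNC(=O)c2ccsc2Cl)cc1` is the unmeasured next member. It differs from compound 2 only in the ring on the carbonyl carbon: 2-chlorothiophen-3-yl in place of thiophen-2-yl on a carbonyl carbon. Within the data shown here, the one measured step, from compound 1 to compound 2, concerns the group on the amide-type nitrogen rather than the ring on the carbonyl carbon, so no measured step bears directly on this change. Among the measured compounds shown here, with no step to lean on, the expectation is a change that stays within the scatter, in either direction. For compound 3 in this assay the estimate is therefore 62%, with a range from 50% to 74%, which means an expected step of a number 0.2 percentage points lower from compound 2 to compound 3 (within the scatter).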

Compound 3, a percentage reported as inhibition, in the whole organism at one dose (the size of the read-out at that dose, not a potency): 52.8%
The estimate for compound 3 lay 9.2 percentage points above the measured number; the measured number falls inside the stated range.
By their numbers in this assay, from the lowest: compounds 1, 3 and 2 (each within the scatter of the next, the first and the last beyond it).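

Among these compounds, this is the first measurement of a change in the ring on the carbonyl carbon: in this assay, putting 2-chlorothiophen-3-yl in place of thiophen-2-yl gives a number 9.4 percentage points lower from compound 2 to compound 3 (within the scatter), so the two groups cannot be told apart at this dose, although the new group differs from the old both by its chlorine and by the ring number at which the thiophene is attached. The clear separation from compound 1 seen in a number 14.4 percentage points higher from compound 1 to compound 2 (beyond the scatter) does not carry over to the chlorinated member, since the comparison now gives a number 5 percentage points higher from compound 1 to compound 3 (within the scatter), which means that the group on the amide-type nitrogen cannot be credited with a gain independent of the ring on the carbonyl carbon. No measurement shown here explains these numbers.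

Still open, going by these compounds, is how the chlorine and the ring number each contribute, which thiophen-3-yl and 5-chlorothiophen-2-yl on the same carbonyl carbon could separate. Also open is whether this position accepts a ring other than thiophene, such as phenyl or furan-2-yl, and how any of these compounds behaves at other doses, as a single dose gives no potency.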